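The source may hold more compounds than are shown below. What is called first, only, known or untested is meant among the compounds shown, and "the series" means these compounds.

Compound 1 `O=C(Nc1nc2ccc(Cl)cc2s1)c1cn(-c2ccccc2)nc1-c1ccccc1`, compound 2 `COc1ccc2nc(NC(=O)c3cn(-c4ccccc4)nc3-c3ccccc3)sc2c1` and compound 3 `O=C(Nc1nc2ccc(Cl)cc2s1)c1cn(-c2ccccc2)nc1-c1ccc(F)cc1` have been tested in an ADME assay on HEK-293T cells (Homo sapiens) for cytotoxicity, read by MTT assay, with a stated time of 72 h (a lower number here means a stronger inhibitor, a higher number a weaker inhibitor), and compound 4 `COc1ccc2nc(NC(=O)c3cn(-c4ccccc4)nc3-c3ccc(F)cc3)sc2c1` has not.

In this assay compound 1 gives 21300 nM. For compound 2 the same assay gives a limit rather than a number, > 50000 nM. Compound 3 gives 45700 nM in this assay.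

Compound 2 differs from compound 1 by methoxy in place of chloro on an aromatic carbon; this change produced an at least 2.3-fold higher number from compound 1 to compound 2 (0.37 log units; beyond the scatter), a step whose size is bounded by the limit of > 50000 nM in this assay, at which 1 of the 3 values shown sits. Compound 3 differs from compound 1 by fluoro in place of hydrogen on an aromatic carbon, which gave a 2.1-fold higher number from compound 1 to compound 3 (0.33 log units; beyond the scatter). The change from compound 3 to compound 4 is methoxy in place of chloro on an aromatic carbon, the same change as that from compound 1 to compound 2, made on a core that carries the fluoro just described.

The earlier step of an at least 2.3-fold higher number from compound 1 to compound 2 (0.37 log units; beyond the scatter) already reached the limit (the limit of > 50000 nM in this assay, at which 1 of the 3 values shown sits). Compound 3 starts from 45700 nM, a higher point than compound 1. On these grounds the expected step of a 2.4-fold higher number from compound 3 to compound 4 (0.38 log units; beyond the scatter) is likely to carry compound 4 beyond what the assay can report. The result is therefore most likely to be another limit. Should a number emerge, compound 4 is estimated at 110000 nM, with a range from 50000 nM to 250000 nM, in this assay.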

Compound 4, half-maximal inhibitory concentration: > 50000 nM
Compound 4: a limit, no number; the forecaster's own chance of this, stated with the estimate: 75%; the middle value is on the limit's open side.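

In this assay compound 4 gives a limit, > 50000 nM, and not a number, which makes it the second compound to stop at that limit: the limit of > 50000 nM in this assay, at which 2 of the 4 values shown sit.

Methoxy in place of chloro on the core that carries the fluoro gave an at least 1.0-fold higher number from compound 3 to compound 4 (0.03 log units; that floor lies within the scatter), a floor that shows no reversal of the step seen on the core of compound 1 but also does not confirm that the step carries over to the new core. The step for fluoro in place of hydrogen between the two methoxy compounds, compound 2 and compound 4, cannot be read, so the methoxy pair adds nothing on that change, and the comparison of the chloro-to-methoxy change on the two cores stays unsettled: the same change on two cores in this assay, an at least 2.3-fold higher number (0.37 log units; beyond the scatter) from compound 1 to compound 2 and an at least 1.0-fold higher number (0.03 log units; that floor lies within the scatter) from compound 3 to compound 4; the limit leaves it open whether they differ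

The compounds shown leave open how far the number for either methoxy compound lies past the limit, and so whether the change has the same size on both cores. They also leave open how an amine or a carboxylic acid on the same aromatic carbon would read in this assay, and whether such a group would give a number rather than a limit.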